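The compounds below may be only part of what the source reports. "The series", "measured", "known", "first", "only" and "open" are said of these compounds alone.

Measured compounds:
compound 1, `O=C(Nc1cccc(-n2cc(-c3ccncc3)c(-c3cc(O)cc(Cl)c3)n2)c1)Nc1ccc(Cl)c(C(F)(F)F)c1`, 31.6%
compound 2, `COc1cc(Cl)cc(-c2nn(-c3cccc(NC(=O)Nc4ccc(Cl)c(C(F)(F)F)c4)c3)cc2-c2ccncc2)c1`, 16.6%
compound 3, `O=C(Nc1cccc(-n2cc(-c3ccncc3)c(-c3cc(O)cc(Cl)c3)n2)c1)c1cc(C(F)(F)F)cc(C(F)(F)F)c1`, 59.6%

In a functional assay on OVCAR-4 cells (Homo sapiens) for inhibition, read by sulforhodamine B assay, with a stated time of 48 h, tested at 10 uM (a higher number here means a weaker effect of the compound at the concentration tested, a lower number a stronger effect), compound 1 gives 31.6%, and compound 2 gives 16.6%. The step between them, (methyl in place of hydrogen on an oxygen on an aromatic ring), is read as a number 15 percentage points lower from compound 1 to compound 2 (beyond the scatter). Compound 3 carries a core that is not the urea core of compound 1; the difference between the two cores is not broken down here. In this assay compound 3 gives 59.6%, which stands as the highest of the three numbers, beyond the scatter from both others.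

Compound 4, `COc1cc(Cl)cc(-c2nn(-c3cccc(NC(=O)c4cc(C(F)(F)F)cc(C(F)(F)F)c4)c3)cc2-c2ccncc2)c1`, has not been measured. It differs from compound 3 by methyl in place of hydrogen on an oxygen on an aromatic ring, the same kind of change as from compound 1 to compound 2, with the same place around it. This change has been seen only once among the compounds tested. The step to compound 4 is expected to be about a number 14.6 percentage points lower from compound 3 to compound 4 (beyond the scatter), resting on a number 15 percentage points lower from compound 1 to compound 2 (beyond the scatter) only, so the width of the expectation is kept broad. Compound 4 is therefore estimated at 45%, within 28% to 62%.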

Compound 4, a percentage reported as activity, at one concentration (the size of the read-out at that concentration, not a potency): 72.1%
Compound 4: the middle estimate sits 27.1 percentage points below what was measured; the measured number lies above the stated range.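

The change from hydroxy to methoxy on the 3-chloro-5-hydroxyphenyl group does not carry over from one core to the other in this assay: the same change on two cores in this assay, a number 15 percentage points lower (beyond the scatter) from compound 1 to compound 2 and a number 12.5 percentage points higher (beyond the scatter) from compound 3 to compound 4, 27.5 percentage points apart, beyond the scatter of two such steps

On the second core the change gives a number 12.5 percentage points higher from compound 3 to compound 4 (beyond the scatter), so the step on the urea core of compound 1 predicts neither the size nor the direction of the step on the other core. With one pair per core, this shows a dependence on the core for these two pairs only; it does not show which part of the core is responsible, and it gives no cause for the reversal.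

The compounds shown leave open how an amine or a longer chain such as ethoxy at the same place would read on either core, and so whether the reversal is specific to methoxy. They also leave open whether the same opposite steps would appear at other concentrations, since a read-out at one concentration is not a potency.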